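Amide nitrogen substituent: from compound 3 to compound 4

The compounds below may be only part of what the source reports. "The series", "measured", "known", "first", "only" and "open" are said of these compounds alone.

Compound 3 `COc1ccc(NC(=O)c2cc(Oc3ccc(/C=C/c4ccncc4)cc3)ccn2)cc1` stands at the limit of a functional assay on HepG2 cells (Homo sapiens) for antiproliferative activity, read by CCK-8 assay, with a stated time of 48 h; on this read-out higher numbers stand for weaker inhibition and lower numbers for stronger inhibition. In this assay compound 3 gives > 100000 nM, which is a limit rather than a number, as the limit of > 100000 nM in this assay, at which 1 of the 3 values shown sits, records. Compound 2 `CNC(=O)c1cc(Oc2ccc(/C=C/c3ccncc3)cc2)ccn1` gives 18200 nM in this assay, and compound 1 `O=C(NCc1ccccc1)c1cc(Oc2ccc(/C=C/c3ccccn3)cc2)ccn1` gives 27900 nM. Among the measured compounds shown here, the only measured single-place step, an at least 5.4-fold higher number from compound 2 to compound 3 (0.73 log units; beyond the scatter), ran toward that limit. Compound 4 `O=C(NCc1ccccc1)c1cc(Oc2ccc(/C=C/c3ccncc3)cc2)ccn1` differs from compound 3 by benzyl in place of 4-methoxyphenyl on an amide-type nitrogen. For the measured compounds named here, no measured step covers benzyl in place of 4-methoxyphenyl directly, but compound 1 also carries benzyl on an amide-type nitrogen and gives a number, 27900 nM, in this assay. For compound 4 the expected step is an at least 4.0-fold lower number from compound 3 to compound 4 (0.60 log units; beyond the scatter). Compound 4 is estimated at 25000 nM, within 8000 nM to 80000 nM.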

Compound 4, half-maximal inhibitory concentration: 28900 nM
The estimate for compound 4 lay 1.2-fold (0.06 log units) below the measured number; measured number inside the range.
By their numbers in this assay, from the lowest: compounds 2, 1 and 4 (each within the scatter of the next). At a limit, above all of these: compound 3.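

Compound 3 stands at a limit, not a number: the limit of > 100000 nM in this assay, at which 1 of the 4 values shown sits.

In this assay, benzyl on the amide-type nitrogen gives an at least 3.4-fold lower number from compound 3 to compound 4 (0.53 log units; beyond the scatter), so the weakness of compound 3 does not extend to benzyl. The other two steps, a 1.6-fold higher number from compound 2 to compound 4 (0.20 log units; within the scatter) and a 1.0-fold higher number from compound 1 to compound 4 (0.02 log units; within the scatter), show methyl and benzyl reading alike on that nitrogen, and pyridin-4-yl and pyridin-2-yl reading alike in the benzyl amide.

A plain phenyl on that nitrogen would separate the effect of the directly attached ring from that of its methoxy group. As far as these compounds go, whether an amine on a longer chain there improves on compound 2 stays open.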